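Three chalcone-like thiazoles all beyond the assay limit

This account rests on a few compounds, and the source may have more. Where it says the series, first, only, none or still open, it means among the compounds named here.

Measured compounds:
Compound 1, `Cc1ccccc1Nc1nc(C)c(C(=O)/C=C/c2ccc(Cl)cc2)s1`, gives > 25000 nM in a functional assay on BGC-823 cells (Homo sapiens) for cytotoxicity, read by MTT assay (a higher number here means a weaker inhibitor, a lower number a stronger inhibitor), which is a limit of the assay and not a number.
Compound 2, `Cc1ccccc1Nc1nc(C)c(C(=O)/C=C/c2ccccc2)s1`, gives > 25000 nM in this assay, again only a limit.
Compound 3, `COc1cccc(/C=C/C(=O)c2sc(Nc3ccccc3C)nc2C)c1`, gives > 25000 nM in this assay, also a limit.

Compound 3 therefore stands nowhere distinct on the numbers shown: its value is a limit, and the same holds for the other two values shown, as the limit of > 25000 nM in this assay, at which 3 of the 3 values shown sit, makes plain. Compound 4, `Cc1ccccc1Nc1nc(C)c(C(=O)/C=C/c2ccccc2Cl)s1`, differs from compound 3 in one place: 2-chlorophenyl in place of 3-methoxyphenyl on a double-bonded chain carbon bound to a double-bonded chain carbon. The measured steps that bear on this change are a step that the two limits leave unreadable from compound 1 to compound 2, a step that the two limits leave unreadable from compound 1 to compound 3 and a step that the two limits leave unreadable from compound 2 to compound 3; each swaps one group on the same double-bonded chain carbon, and none of them can be read in size, since both ends sit at the limit. No readable step exists in either direction, so no step beyond the scatter can be expected from compound 3 to compound 4, and the estimated step is a step that the limit leaves unreadable from compound 3 to compound 4. Compound 4 is expected to give about 30000 nM in this assay, within a range of 10000 nM to 100000 nM, most likely reported once more as a limit.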

Compound 4, half-maximal inhibitory concentration: > 25000 nM
Compound 4: only a limit was reported; the forecaster's own chance of this, stated with the estimate: 85%; the middle value does not contradict the limit.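

Compound 4 sits at a limit, as do compound 1, compound 2 and compound 3, so no step among them can be read in size: the limit of > 25000 nM in this assay, at which 4 of the 4 values shown sit.

The compounds shown leave open how strong any of them truly is, and whether any other group in this place would give a readable value in this assay.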